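Swapping the hydroxycarbamoyl phenyl for a fluoroindazole

The source may hold more compounds than are shown below. What is called first, only, known or untested is meant among the compounds shown, and "the series" means these compounds.

Measured so far:
compound 1, `O=C(NO)c1ccc(N(Cc2ccc(C3CCCCC3)cn2)C(=O)[C@H]2CCN2S(=O)(=O)c2c(F)c(F)c(F)c(F)c2F)c(F)c1` — 5800 nM
compound 2, `O=C(NO)c1ccc(N(Cc2cnc(C3CCCCC3)cn2)C(=O)[C@H]2CCN2S(=O)(=O)c2c(F)c(F)c(F)c(F)c2F)c(F)c1` — "not determined" (no result reported)

The measurement in question is a functional assay on MDA-MB-231 cells (Homo sapiens) for antiproliferative activity, with a stated time of 72 h; a higher number here means that more compound is needed for the effect, a lower number that less compound is needed. Within the data shown here, compound 1 is the only compound with a number: in this assay compound 1 gives 5800 nM, so it stands alone and there is no second value to compare it with. Compound 2 shares most of its structure with compound 1 but in this assay compound 2 gives "not determined" (no result reported), so nothing can be read from the pair.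

Compound 3, `O=C([C@H]1CCN1S(=O)(=O)c1c(F)c(F)c(F)c(F)c1F)N(Cc1ccc(C2CCCCC2)cn1)c1cc2[nH]ncc2cc1F`, has not been measured yet. It differs from compound 1 in one place: 5-fluoro-1H-indazol-6-yl in place of 2-fluoro-4-(hydroxycarbamoyl)phenyl on an amide-type nitrogen. The group that leaves carries two hydrogen-bond donors and two acceptors; the one that enters carries one of each, with a two-ring aromatic system in place of a single ring.

Among the measured compounds shown here, no step between measured compounds exists to anchor an expectation, so the estimate rests on the size of this change alone. The step from compound 1 to compound 3 is expected to run toward a higher number, by a 2.6-fold higher number from compound 1 to compound 3 (0.41 log units; beyond the scatter), beyond the usual scatter. Compound 3 is therefore estimated at 15000 nM, within a range from 4000 nM to 50000 nM.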

Compound 3, half-maximal effective concentration: 2300 nM
Estimate against measurement, compound 3: 6.5-fold (0.81 log units) above, outside the stated range (below it).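

Replacing 2-fluoro-4-(hydroxycarbamoyl)phenyl with 5-fluoro-1H-indazol-6-yl on the amide-type nitrogen gives a 2.5-fold lower number from compound 1 to compound 3 (0.40 log units; beyond the scatter) in this assay, so the hydroxycarbamoyl group is not needed to keep this antiproliferative activity in this series. Among these compounds, this is the first comparison the set allows, and it shows that this place accepts a two-ring aromatic group with fewer hydrogen-bond donors and acceptors, with a modest shift toward less compound being needed. Nothing measured here explains why the number moves in this direction.

The change removes the hydroxycarbamoyl group and brings in the indazole in a single step, so the compounds shown cannot separate the effect of losing one from that of gaining the other. A phenyl ring carrying a carboxylic acid in place of the hydroxycarbamoyl group, or an indazole with no fluorine, would be the kind of neighbour needed to tell these apart, and a single pair cannot show whether the same swap behaves alike on other versions of the core.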